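From compound 2 to compound 4: replacing methoxy

A few compounds are considered here, and "the series" means these few. Any claim that something is new, unique, unknown or untested is made for them only; others in the source may bear on it.

Of the compounds shown here, three on one shared core have been measured so far in an ADME assay on a cell-free system (plasma, Homo sapiens) (a higher number here means a larger unbound share of the compound, a lower number a smaller unbound share), and they lie within the scatter of one another. Compound 1 `CCNC(=O)Nc1nc2cc(-c3cncc(F)c3)c(=O)n(C(C)C)c2s1` reads 0.1 in this set, compound 3 `CCNC(=O)Nc1nc2cc(-c3cncc(OC)c3)c(=O)n(C(C)C)c2s1` reads 0.08 and compound 2 `CCNC(=O)Nc1nc2cc(-c3ccc(OC)nc3)c(=O)n(C(C)C)c2s1` reads 0.05 as its own number.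

Compound 4 `CCNC(=O)Nc1nc2cc(-c3ccc(-c4nnn(C)n4)nc3)c(=O)n(C(C)C)c2s1` departs from compound 2 at one place only. The difference is 2-methyl-2H-tetrazol-5-yl in place of methoxy on an aromatic carbon and amounts to 2-methyl-2H-tetrazol-5-yl in place of methoxy on an aromatic carbon, next to the ring nitrogen and para to a large group.

The measured steps bear on this only loosely. Moving the methoxy group gave a 1.6-fold higher number from compound 2 to compound 3 (0.20 log units; within the scatter) while methoxy in place of fluoro gave a 1.3-fold lower number from compound 1 to compound 3 (0.10 log units; within the scatter) and 6-methoxypyridin-3-yl in place of 5-fluoropyridin-3-yl gave a 2.0-fold lower number from compound 1 to compound 2 (0.30 log units; within the scatter) across the set. Within the data shown here, none of these steps puts a ring at this place, so the series offers no direct precedent for the incoming group.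

On those steps no shift beyond the scatter is expected in this assay and the estimated step is no change at the digits printed from compound 2 to compound 4 (within the scatter) with either direction open. For compound 4 the estimated unbound fraction is 0.05 with an expected range of 0.025 to 0.1 around it.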

Compound 4, unbound fraction: 0.08
Compound 4: middle estimate off by 1.6-fold (0.20 log units), on the low side; low and high end bracket the measured number.
By their numbers in this assay, from the lowest: compounds 2, 3, 4 and 1 (each within the scatter of the next).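

In this assay, 2-methyl-2H-tetrazol-5-yl in place of methoxy on the aromatic carbon next to the ring nitrogen and para to a large group gives a 1.6-fold higher number from compound 2 to compound 4 (0.20 log units; within the scatter). Among these compounds, this is the first reading for a ring at this place, and it shows that a five-membered aromatic ring with 4 hetero atoms, with 6 heavy atoms and 4 hydrogen-bond acceptors entering where 2 heavy atoms and 1 hydrogen-bond acceptor leave, produces no shift beyond the scatter in the unbound fraction. No supporting data are available to explain the size of this step.

The four compounds shown all lie within the scatter of one another, so the series does not yet identify any change that moves this read-out beyond it. Going by these compounds, it remains open whether an amine, a carboxylic acid or a longer alkoxy chain at this same place would also stay within the scatter of compound 2, or whether another five-membered ring would behave like 2-methyl-2H-tetrazol-5-yl.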